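Side-chain change from compound 2 to compound 3

The source may hold more compounds than are shown below. What is called first, only, known or untested is meant among the compounds shown, and "the series" means these compounds.

Measured in a functional assay on KB cells (Homo sapiens) for antiproliferative activity, read by MTT assay, with a stated time of 48 h; a lower number here means a stronger inhibitor, a higher number a weaker inhibitor:
- compound 1 (`Cn1cc(C2=C(c3nn(CCCN4CCCCC4)c4ncccc34)C(=O)N(c3ccccn3)C2=O)c2ccccc21`): > 100000 nM (a limit)
- compound 2 (`CN1CCN(CCCn2nc(C3=C(c4cn(C)c5ccccc45)C(=O)NC3=O)c3cccnc32)CC1`): > 100000 nM (a limit)

Compound 2 has no number in this assay, only the limit > 100000 nM. Compound 1 likewise gives only a limit. Among the compounds with values here, the series so far shows (the limit of > 100000 nM in this assay, at which 2 of the 2 values shown sit).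

Compound 3 (`Cn1cc(C2=C(c3nn(CCn4ccnc4)c4ncccc34)C(=O)NC2=O)c2ccccc21`), not yet measured, differs from compound 2 as follows: 1H-imidazol-1-yl in place of (4-methylpiperazin-1-yl)methyl on a saturated chain carbon, two bonds along the chain from an aromatic nitrogen. This places 1H-imidazol-1-yl where (4-methylpiperazin-1-yl)methyl stood, on a saturated chain carbon, two bonds along the chain from an aromatic nitrogen.

No measured step sizes this change. In this assay only a small gain in strength, or none, is expected, and a further limit is quite possible. The estimated change is an at least 1.6-fold lower number from compound 2 to compound 3 (0.22 log units; that floor lies within the scatter). For compound 3 the expected value is 60000 nM, with an estimated range from 10000 nM to 100000 nM.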

Compound 3, half-maximal inhibitory concentration: > 100000 nM
Compound 3: no number, only a limit (the forecaster's own chance of this, stated with the estimate: 65%); middle value at least 1.6-fold (0.22 log units) away from the limit.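

In this assay compound 3 gives > 100000 nM, a limit. Within the data shown here, compound 2 also gives only a limit, so no step from compound 2 to compound 3 can be read. The compounds shown leave open whether any side chain on the shared core gives a measurable number in this assay: the limit of > 100000 nM in this assay, at which 3 of the 3 values shown sit.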